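A Fluoro for a Chloro in Compound 4

A few compounds are considered here, and "the series" means these few. Any claim that something is new, unique, unknown or untested is made for them only; others in the source may bear on it.

In a physicochemical assay (on this read-out lower numbers stand for an effect already at smaller amounts and higher numbers for an effect only at larger amounts of compound), compound 1 `COc1cc(/C=N/NC(=O)c2nn(-c3ccc(Cl)cc3Cl)c(-c3ccc(Cl)cc3)c2C)ccc1O` gives 3550000 nM, compound 2 `COc1cc(/C=N/NC(=O)c2nn(-c3ccc(Cl)cc3Cl)c(-c3ccccc3)c2C)ccc1O` gives 2990000 nM, and compound 3 `COc1cc(/C=N/NC(=O)c2nn(-c3ccc(Cl)c(Cl)c3)c(-c3ccc(Cl)cc3)c2C)ccc1O` gives 2600000 nM. All three values lie within the scatter of one another, so compound 3 stands level with the other two.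

Compound 4 `COc1cc(/C=N/NC(=O)c2nn(-c3ccc(F)c(Cl)c3)c(-c3ccc(Cl)cc3)c2C)ccc1O` has fluoro in place of chloro on an aromatic carbon, ortho to a chloro group and para to a large group: fluoro in place of chloro on an aromatic carbon. Among the measured compounds shown here, no measured step makes this exact exchange. The closest are a 1.2-fold lower number from compound 1 to compound 2 (0.07 log units; within the scatter), with hydrogen in place of chloro, and a 1.4-fold lower number from compound 1 to compound 3 (0.14 log units; within the scatter), with 3,4-dichlorophenyl in place of 2,4-dichlorophenyl. Neither leaves the scatter, so no step beyond it is expected in this assay. The estimated step is a 1.0-fold higher number from compound 3 to compound 4 (0.02 log units; within the scatter). For compound 4 the estimated value is 2700000 nM, with an expected range of 1700000 nM to 4200000 nM.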

Compound 4, half-maximal effective concentration: 3560000 nM
Compound 4: the middle estimate sits 1.3-fold (0.12 log units) below what was measured; low and high end bracket the measured number.
By their numbers in this assay, from the lowest: compounds 3, 2, 1 and 4 (each within the scatter of the next).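

In this assay, among the compounds shown here, fluoro in place of chloro, ortho to a chloro group and para to a large group, gives a 1.4-fold higher number from compound 3 to compound 4 (0.14 log units; within the scatter), so the first exchange at this position leaves the compounds level. Against compound 1, 3-chloro-4-fluorophenyl in place of 2,4-dichlorophenyl gives a 1.0-fold higher number from compound 1 to compound 4 (0.00 log units; within the scatter), so a second halogen pattern on this aryl group also stays within the scatter. No measurement at hand explains this flat response.

On these data alone, both groups at this position are single halogen atoms, so it remains open whether an amine, a carboxylic acid or a longer chain there would leave the scatter. As far as these compounds go, whether hydrogen in this place would read the same also remains open.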